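Chloro and methyl placement on the sulfonamide nitrogen's phenyl group

The source may report more compounds than this note shows. Statements on the series, on what has been measured and on what is new or still open speak of the compounds shown alone.

In a functional assay on cells (leukaemia cell line, Homo sapiens) for inhibition, read by sulforhodamine B assay, with a stated time of 48 h (on this read-out higher numbers stand for weaker inhibition of growth and lower numbers for stronger inhibition of growth), compound 1 (`O=S(=O)(Nc1ccccc1Cl)c1ccc(-c2cnc(C3CC3)o2)cc1`) gives 429 nM, compound 2 (`O=S(=O)(Nc1cccc(Cl)c1)c1ccc(-c2cnc(C3CC3)o2)cc1`) gives 477 nM and compound 3 (`Cc1cc(Cl)ccc1NS(=O)(=O)c1ccc(-c2cnc(C3CC3)o2)cc1`) gives 277 nM. These three values lie within the scatter of one another, so compound 3 does not stand apart from the other two.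

Compound 4 (`Cc1cc(Cl)cc(NS(=O)(=O)c2ccc(-c3cnc(C4CC4)o3)cc2)c1`) has the same atoms as compound 3, joined differently: 3-chloro-5-methylphenyl in place of 4-chloro-2-methylphenyl on a sulfonamide nitrogen.

Among the measured compounds shown here, three measured steps bear on this change. Exchanging one chlorophenyl group for the other gives a 1.1-fold higher number from compound 1 to compound 2 (0.05 log units; within the scatter). Going to the 4-chloro-2-methylphenyl group gives a 1.5-fold lower number from compound 1 to compound 3 (0.19 log units; within the scatter) and a 1.7-fold lower number from compound 2 to compound 3 (0.24 log units; within the scatter). For the measured compounds named here, all three stay within the scatter, although no measured compound carries the 3-chloro-5-methylphenyl group, so that particular arrangement remains untested. The closest measured comparison is compound 2 at 477 nM, which carries a 3-chlorophenyl group.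

No step beyond the scatter is therefore expected in this assay. The estimated change is a 1.4-fold higher number from compound 3 to compound 4 (0.14 log units; within the scatter), and its direction is not firmly set by these data. For compound 4 the expected value is 380 nM, with an estimated range of 170 nM to 850 nM.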

Compound 4, concentration for 50% growth inhibition: 175 nM
Compound 4: the middle estimate sits 2.2-fold (0.34 log units) above what was measured; low and high end bracket the measured number.
By their numbers in this assay, from the lowest: compounds 4, 3, 1 and 2 (each within the scatter of the next, the first and the last beyond it).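

In this assay, among the compounds shown here, the 3-chloro-5-methylphenyl group on the sulfonamide nitrogen gives the first steps in this set that pass the scatter, though both are modest: methyl in place of hydrogen on an aromatic carbon gives one (a 2.7-fold lower number from compound 2 to compound 4 (0.44 log units; beyond the scatter)), and 3-chloro-5-methylphenyl in place of 2-chlorophenyl gives the other (a 2.5-fold lower number from compound 1 to compound 4 (0.39 log units; beyond the scatter)). The direct exchange of the two arrangements of the same atoms does not separate them (a 1.6-fold lower number from compound 3 to compound 4 (0.20 log units; within the scatter)), so compound 3 and compound 4 count as equal on this read-out, and only compound 4 stands clearly apart from the two chlorophenyl compounds. No measurement at hand offers any explanation for these differences.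

On these data alone, whether a methyl group is specifically required stays open, since a methoxy or trifluoromethyl group in its place on the 3-chlorophenyl group would test whether the step from the 3-chlorophenyl compound holds for other groups. Also open, as far as these compounds go, is how an amine or a carboxylic acid on this phenyl group would read in this assay, and whether the cyclopropyl group of the shared core can be exchanged for a longer chain without losing the step.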